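This account rests on a few compounds, and the source may have more. Where it says the series, first, only, none or still open, it means among the compounds named here.

In an ADME assay on HEK293 cells (Homo sapiens) for cytotoxicity, read by reporter gene assay and resazurin assay, with a stated time of 48 h (a higher number here means that more compound is tolerated, a lower number that less compound is tolerated), compound 1 `COc1c(Br)cc(Br)cc1C(=O)Nc1ccccc1` gives > 100000 nM, which is a limit of the assay rather than a number. Compound 3 `O=C(Nc1ccccc1)c1cc(Br)cc(Br)c1O` gives 34000 nM in this assay, and compound 2 `O=C(Nc1cccc(Cl)c1)c1ccccc1O` gives 37000 nM; these two values lie within the scatter of each other. Compound 1 and compound 3 differ by methyl in place of hydrogen on an oxygen on an aromatic ring, and this change brings an at least 2.9-fold higher number from compound 3 to compound 1 (0.46 log units; beyond the scatter). The step is open-ended because the limit of > 100000 nM in this assay, at which 1 of the 3 values shown sits, is where compound 1 sits.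

Compound 4 `COc1ccccc1C(=O)Nc1cccc(Cl)c1` has not yet been measured. It differs from compound 2 by methyl in place of hydrogen on an oxygen on an aromatic ring, the same change that separates compound 3 from compound 1. The difference between the core of compound 2 and the core of compound 3 is not broken down here.

Resting on an at least 2.9-fold higher number from compound 3 to compound 1 (0.46 log units; beyond the scatter) and on the value of compound 2, 37000 nM, compound 4 is expected to show a 2.4-fold higher number from compound 2 to compound 4 (0.39 log units; beyond the scatter) in this assay. Compound 4 is accordingly estimated at 90000 nM, with a likely range from 40000 nM to 200000 nM, and a real chance that only a limit is returned.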

Compound 4, half-maximal cytotoxic concentration: > 100000 nM
Compound 4: a limit, no number; the forecaster's own chance of this, stated with the estimate: 50%; middle value at least 1.1-fold (0.04 log units) away from the limit.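

In this assay compound 4 gives > 100000 nM, which is a limit of the assay and not a number. Methyl in place of hydrogen on the oxygen brings an at least 2.7-fold higher number from compound 2 to compound 4 (0.43 log units; beyond the scatter), so hydroxy to methoxy moves the number the same way on both cores shown, each step lying beyond the scatter: the same change on two cores in this assay, an at least 2.9-fold higher number (0.46 log units; beyond the scatter) from compound 3 to compound 1 and an at least 2.7-fold higher number (0.43 log units; beyond the scatter) from compound 2 to compound 4; the limit leaves it open whether they differ. This does not show the true size of either step, nor whether one core responds more strongly than the other, since both methoxy compounds stop at the same limit: the limit of > 100000 nM in this assay, at which 2 of the 4 values shown sit.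

The compounds shown leave open whether a longer chain on that oxygen, such as ethoxy, or an amine or a carboxylic acid in place of the hydroxy group, would move the number the same way in this assay. Also open is whether the methyl change would carry over to further cores, as only two are shown here and neither step has a number at its upper end.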